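Cyclobutyl in Place of 2-Hydroxyethyl: Expected Shift in Affinity

The source may hold more compounds than are shown below. What is called first, only, known or untested is meant among the compounds shown, and "the series" means these compounds.

Compound 1, `CCNc1nc(-c2ccccc2)nc2c1nnn2Cc1ccccc1Cl`: 463000000 nM
Compound 2, `Clc1ccccc1Cn1nnc2c(NC3CCCC3)nc(-c3ccccc3)nc21`: 9000000 nM
Compound 3, `OCCNc1nc(-c2ccccc2)nc2c1nnn2Cc1ccccc1Cl`: 116000000 nM

In an assay on isolated protein for binding affinity to adenosine receptor A1 (Bos taurus) (on this read-out higher numbers stand for weaker inhibition and lower numbers for stronger inhibition), compound 3 stands second highest of the three numbers. It is separated from compound 1 by the modest step of a 4.0-fold lower number from compound 1 to compound 3 (0.60 log units; beyond the scatter) and from compound 2 by the large step of a 13-fold higher number from compound 2 to compound 3 (1.11 log units; beyond the scatter).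

Compound 4, `Clc1ccccc1Cn1nnc2c(NC3CCC3)nc(-c3ccccc3)nc21`, differs from compound 3 by cyclobutyl in place of 2-hydroxyethyl on a nitrogen on an aromatic ring. The step that bears on this is a 13-fold higher number from compound 2 to compound 3 (1.11 log units; beyond the scatter), in which a cycloalkyl group on the same nitrogen gave a far lower number than the 2-hydroxyethyl group. With a ring one carbon smaller than cyclopentyl, compound 4 is expected to move in the same direction as compound 2, though not quite as far. For compound 4 the expected step is estimated as a 5.8-fold lower number from compound 3 to compound 4 (0.76 log units; beyond the scatter). Compound 4 is therefore estimated at 20000000 nM, with a range from 5000000 nM to 80000000 nM.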

Compound 4, inhibition constant: 24000000 nM
For compound 4 the middle estimate is 1.2-fold (0.08 log units) below the measured one; low and high end bracket the measured number.
By their numbers in this assay, from the lowest: compound 2; then compound 4; then compound 3; then compound 1.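

In this assay the lower number at this nitrogen is not peculiar to cyclopentyl, for cyclobutyl also gives a 4.8-fold lower number from compound 3 to compound 4 (0.68 log units; beyond the scatter) against 2-hydroxyethyl and a 19-fold lower number from compound 1 to compound 4 (1.29 log units; beyond the scatter) against ethyl. Ring size still registers, with a 2.7-fold higher number from compound 2 to compound 4 (0.43 log units; beyond the scatter) on going from cyclopentyl to the smaller ring, a step beyond the usual scatter. Nothing measured here accounts for these shifts. From the compounds shown here alone, whether a cyclopropyl or a cyclohexyl ring on this nitrogen would extend the order from cyclobutyl to cyclopentyl stays open. So does the effect of a hydroxy group placed on a cyclobutyl ring.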